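A few compounds are considered here, and "the series" means these few. Any claim that something is new, unique, unknown or untested is made for them only; others in the source may bear on it.

Measured in a functional assay on BT-549 cells (Homo sapiens) for antiproliferative activity, read by MTT assay, with a stated time of 48 h; on this read-out lower numbers stand for stronger inhibition and higher numbers for weaker inhibition:
Compound 1 `CN1C(=O)C(O)(Cc2nnn[nH]2)c2cc(F)ccc21`: > 100000 nM
Compound 2 `O=C1N(Cc2ccc(Br)cc2)c2ccc(F)cc2C1(O)Cc1nnn[nH]1`: > 100000 nM

Compound 1 stands only at a limit of this assay, and no number is known for it. Compound 2 also gives only a limit. Among the measured compounds shown here, the one measured step is a step that the two limits leave unreadable from compound 1 to compound 2, so it offers no size to carry over, and it lies at a different place on the structure. Both compounds sit at the limit of > 100000 nM in this assay, at which 2 of the 2 values shown sit.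

Compound 3 `CN1C(=O)C(O)(Cc2nnn[nH]2)c2cc(Br)ccc21` differs from compound 1 by bromo in place of fluoro on an aromatic carbon. For the measured compounds named here, no measured step covers this exchange. With compound 1 at > 100000 nM, no step beyond the scatter is expected in this assay, and a further limit is the likeliest report. The estimated step is a number no higher from compound 1 to compound 3 (the limit leaves the size open). Compound 3 is expected at 100000 nM, with an estimated range of 40000 nM to 200000 nM.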

Compound 3, half-maximal inhibitory concentration: > 100000 nM
Compound 3: no number, only a limit (the forecaster's own chance of this, stated with the estimate: 85%); the middle value sits exactly at the limit.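

Compound 1 and compound 3 both give only a limit in this assay, so no step can be read for bromo in place of fluoro on an aromatic carbon. The compounds shown leave open which change to the shared core, if any, would give a measurable value: the limit of > 100000 nM in this assay, at which 3 of the 3 values shown sit.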